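Replacing the dimethylphenyl amide with a thiazolyl amide

This account rests on a few compounds, and the source may have more. Where it says the series, first, only, none or still open, it means among the compounds named here.

For the measured compounds named here, compound 3 `COc1ccc2nc(C)cc(OCC(=O)Nc3cc(C)c(F)c(C)c3)c2c1` gives 5.5 in a physicochemical assay for lipophilicity, read by HPLC, in phosphate buffer, measured as chromatographic lipophilicity, at pH 7.4 (on this read-out lower numbers stand for lower lipophilicity and higher numbers for higher lipophilicity), which places it second highest of the three numbers known so far. Its nearest neighbour is compound 2 `COc1ccc2nc(C)cc(OCC(=O)Nc3cc(C)c(OC)c(C)c3)c2c1`, at 4.99, and the furthest is compound 1 `CSc1ccc2nc(C)cc(OCC(=O)Nc3cc(C)cc(C)c3)c2c1`, at 6.42. Going by the values given here, the only step between measured compounds that differ in one place is a number 0.51 log units higher from compound 2 to compound 3 (beyond the scatter).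

Compound 4 `COc1ccc2nc(C)cc(OCC(=O)Nc3nccs3)c2c1` differs from compound 3 in one place: 1,3-thiazol-2-yl in place of 4-fluoro-3,5-dimethylphenyl on an amide-type nitrogen. Among the compounds with values here, none of the measured steps covers an exchange of this kind; the step from compound 2 to compound 3 concerns a single substituent on the same carbon-only ring, whereas here the whole ring leaves and a five-membered ring with 2 hetero atoms and 2 hydrogen-bond acceptors enters. Compound 4 is therefore expected to fall well below compound 3, by a step of a number 1.50 log units lower from compound 3 to compound 4 (beyond the scatter), larger than anything seen among the measured pairs. The estimate for compound 4 in this assay is 4, with a range from 3.3 to 4.7.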

Compound 4, distribution coefficient: 3.2
Compound 4: middle estimate off by 0.80 log units, on the high side, and the stated range ends above it.
By their numbers in this assay, from the lowest: compound 4; then compound 2; then compound 3; then compound 1.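

The group on the amide-type nitrogen proves a far more sensitive place than the aromatic carbon of the earlier pair: in this assay the exchange of 4-fluoro-3,5-dimethylphenyl for 1,3-thiazol-2-yl gives a number 2.30 log units lower from compound 3 to compound 4 (beyond the scatter) and so outruns the single-substituent change, which gave a number 0.51 log units higher from compound 2 to compound 3 (beyond the scatter) on the same read-out. This exchange alters ring size and ring atoms together, so this one step cannot separate the contribution of each. Nothing at hand accounts for the size of the step.

The compounds shown leave open whether a pyridyl group or a methyl-bearing 1,3-thiazol-2-yl on the same nitrogen would fall nearer to compound 3 or to compound 4. They also leave open whether the same exchange would give a step of similar size starting from compound 1.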